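The source may hold more compounds than are shown below. What is called first, only, known or untested is meant among the compounds shown, and "the series" means these compounds.

Measured in an ADME assay on Caco-2 cells (Homo sapiens) for permeability, read by LC-MS, with a stated time of 2 h; on this read-out higher numbers stand for higher permeability and lower numbers for lower permeability:
- compound 1 `CCCN(Cc1ccc(OCCN2C(=O)CCC2=O)c(C)c1)C(CC(=O)O)c1ccc(Cl)cc1`: 10.2 nm/s
- compound 2 `CCN(Cc1ccc(OCCN2C(=O)CCC2=O)c(C)c1)C(CC(=O)O)c1ccc(Cl)cc1`: 3.9 nm/s
- compound 3 `CCN(Cc1ccc(OCCn2c(=O)ccn(C)c2=O)c(C)c1)C(CC(=O)O)c1ccc(Cl)cc1`: 2.1 nm/s

Compound 3, at 2.1 nm/s, lies within the scatter of compound 2 and clearly under compound 1. The next structure, compound 4 `Cc1cc(CN(C2CCC2)C(CC(=O)O)c2ccc(Cl)cc2)ccc1OCCn1c(=O)ccn(C)c1=O`, differs from compound 3 by cyclobutyl in place of ethyl on an amine nitrogen.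

Going by the values given here, only one measured step touches this part of the molecule. That step is a 2.6-fold lower number from compound 1 to compound 2 (0.42 log units; beyond the scatter), with hydrogen in place of methyl on a saturated chain carbon, two bonds along the chain from an amine nitrogen. It is modest but beyond the scatter, and the number falls as the carbon is lost. The other step, a 1.9-fold lower number from compound 2 to compound 3 (0.27 log units; within the scatter), lies within the scatter and concerns a different place. Among the compounds with values here, no compound with a ring on this nitrogen has been measured, so the comparison is loose. A rise of similar size is nevertheless expected, on the strength of the change seen in a 2.6-fold lower number from compound 1 to compound 2 (0.42 log units; beyond the scatter).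

The expected change is a 2.6-fold higher number from compound 3 to compound 4 (0.42 log units; beyond the scatter). For compound 4 the estimated value is 5.5 nm/s, within an expected range of 2.5 nm/s to 12 nm/s.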

Compound 4, apparent permeability: 5 nm/s
Estimate against measurement, compound 4: 1.1-fold (0.04 log units) above, within the range that was stated.
By their numbers in this assay, from the lowest: compounds 3, 2 and 4 (each within the scatter of the next, the first and the last beyond it); then compound 1.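

Cyclobutyl in place of ethyl is the first change shown that puts a ring on the amine nitrogen, and in this assay it gives a 2.4-fold higher number from compound 3 to compound 4 (0.38 log units; beyond the scatter) as a modest step. The earlier step on this side of the molecule was seen in compounds with the five-membered non-aromatic ring group, whereas this one is seen in compounds with the six-membered aromatic group, so a step beyond the scatter at this nitrogen is no longer tied to one of them. Alongside a 2.6-fold lower number from compound 1 to compound 2 (0.42 log units; beyond the scatter) in the other series, the group with more carbon on this nitrogen carries the higher number in both pairs, and no compound shown goes against that.

As far as these compounds go, whether the ring or the added carbon carries the step stays open, and a butyl or a cyclopropyl group on this nitrogen would separate the two. Nothing on hand gives a cause for either step.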